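Taking One Methyl from Compound 2

The compounds below may be only part of what the source reports. "The series", "measured", "known", "first", "only" and "open" are said of these compounds alone.

In a functional assay on SF-295 cells (Homo sapiens) for antiproliferative activity (a higher number here means a weaker inhibitor of growth, a lower number a stronger inhibitor of growth), compound 1 `Cc1ccnc2nc(-c3cccc4ccccc34)cc(O)c12` gives 10.7 nM and compound 3 `Cc1cnc2[nH]c(-c3cccc(F)c3)cc(=O)c2c1` gives 27.5 nM as its value. Compound 2 `Cc1cc(C)c2c(O)cc(-c3cccc4ccccc34)nc2n1` stands at 589 nM as the highest of the three numbers, beyond the scatter from both others.

Compound 4 `Cc1ccc2c(O)cc(-c3cccc4ccccc34)nc2n1` differs from compound 2 by hydrogen in place of methyl on an aromatic carbon with hydrogen in place of methyl on an aromatic carbon, opposite the ring nitrogen.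

Among the compounds with values here, one measured step bears on this change. It is large: a 55-fold higher number from compound 1 to compound 2 (1.74 log units; beyond the scatter) with methyl in place of hydrogen on an aromatic carbon. Within the data shown here, that added methyl stays in compound 4, while the methyl that leaves is the one compound 1 also carries. Among the measured compounds shown here, compound 4 is therefore not compound 1 again, and no measured step covers the loss of this methyl. Given a 55-fold higher number from compound 1 to compound 2 (1.74 log units; beyond the scatter) on adding the methyl that stays, much of the high number is expected to remain, with only a moderate fall. The expected change is a 4.9-fold lower number from compound 2 to compound 4 (0.69 log units; beyond the scatter) as an estimate. For compound 4 the estimated value is 120 nM with an expected range from 25 nM to 500 nM in this assay.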

Compound 4, concentration for 50% growth inhibition: 24 nM
Estimate against measurement, compound 4: 5.0-fold (0.70 log units) above; the whole stated range lies above it.
By their numbers in this assay, from the lowest: compound 1; then compounds 4 and 3 (each within the scatter of the next); then compound 2.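

Removing the methyl opposite the ring nitrogen gives a 25-fold lower number from compound 2 to compound 4 (1.39 log units; beyond the scatter) in this assay, so this position is far from silent in compound 2. The earlier step, a 55-fold higher number from compound 1 to compound 2 (1.74 log units; beyond the scatter), had tied the high number of compound 2 to its other methyl, but each of the two methyls now proves to matter: with either one replaced by hydrogen, the number falls by a large step. No measurement shown here explains why this methyl has so large an effect.

Going by these compounds, what the number would be with hydrogen at both places remains open, as does whether the step at this position would hold with the fluorophenyl group of compound 3 in place of the naphthyl group. Nor do these compounds tell how an ethyl group, a methoxy group or an amine would behave opposite the ring nitrogen.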